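A few compounds are considered here, and "the series" means these few. Any claim that something is new, unique, unknown or untested is made for them only; others in the source may bear on it.

Of the compounds shown here, three have been measured in an assay for inhibition of 15-hydroxyprostaglandin dehydrogenase [NAD(+)] (Homo sapiens), read by fluorescence, with a stated time of 15 min, in the presence of a further agent that is not named here; a higher number here means a weaker inhibitor, a lower number a stronger inhibitor.
Compound 1 `CCCC[S+]([O-])c1sc2nc(-c3nccs3)cc(-c3cccc(CO)c3)c2c1N` gives 4.3 nM.
Compound 2 `CCOC(=O)c1sc2nc(-c3cccs3)cc(-c3ccccc3)c2c1N` gives only a limit of the assay, > 7500 nM.
Compound 3 `CCC[S+]([O-])c1sc2ncccc2c1N` gives 151 nM.

Of the two plain numbers, compound 1 holds the lower one; compound 3 is nearest, with a higher number, and that gap is beyond the scatter. Among the measured compounds shown here, no two measured compounds differ in one place only, so no single step has been seen. Compound 4 `CCCC[S+]([O-])c1sc2nc(-c3nccs3)cc(-c3ccc(C(=O)OC)cc3)c2c1N` differs from compound 1 by 4-(methoxycarbonyl)phenyl in place of 3-(hydroxymethyl)phenyl on an aromatic carbon. Nothing measured shows what such a change does, so the expectation rests on thin ground. A small step is expected, a 1.9-fold higher number from compound 1 to compound 4 (0.27 log units; within the scatter), toward a somewhat higher number, not clearly beyond the scatter. Compound 4 is therefore expected to give 8 nM in this assay, between 2 nM and 40 nM.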

Compound 4, half-maximal inhibitory concentration: 15.1 nM
For compound 4 the middle estimate is 1.9-fold (0.28 log units) below the measured one; measured number inside the range.
By their numbers in this assay, from the lowest: compound 1; then compound 4; then compound 3. At a limit, above all of these: compound 2.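

Among the compounds shown here, this is the first step seen at the aromatic carbon opposite the ring nitrogen, and swapping 3-(hydroxymethyl)phenyl for 4-(methoxycarbonyl)phenyl gives a 3.5-fold higher number from compound 1 to compound 4 (0.55 log units; beyond the scatter) in this assay. The entering group has no hydrogen-bond donors, yet compound 4 still gives 15.1 nM, so a hydrogen-bond donor on this phenyl is not needed for a low number. The attachment point and the group itself change together, so the step cannot be divided between them.

On these data alone, how 3-(methoxycarbonyl)phenyl, or a phenyl carrying an amine or a carboxylic acid, would read remains open. Nothing shown bears on why the number rose.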